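The source may hold more compounds than are shown below. What is called first, only, known or untested is meant among the compounds shown, and "the series" means these compounds.

Measured compounds:
compound 1 `c1ccc(-c2cccc3c2C2CNCC3C2)cc1` gives 1600 nM
compound 2 `FC(F)(F)c1cccc2c1C1CNCC2C1` gives 39 nM

In an assay on HEK293 cells for binding affinity to Neuronal acetylcholine receptor; alpha4/beta2 (Homo sapiens) (on this read-out lower numbers stand for stronger inhibition and higher numbers for weaker inhibition), compound 2 stands at the lowest of the two numbers; its nearest neighbour is compound 1, and the step of a 41-fold lower number from compound 1 to compound 2 (1.61 log units; beyond the scatter) is large. Compound 3 `Oc1cccc2c1C1CNCC2C1` differs from compound 2 by hydroxy in place of trifluoromethyl on an aromatic carbon. Among the measured compounds shown here, the only measured step swaps a phenyl for a trifluoromethyl at this position, so no measured step directly shows what a hydroxy does there; the single step only shows that this position is sensitive to what sits on it. Compound 3 is therefore expected near compound 2, with a modest change a 1.5-fold higher number from compound 2 to compound 3 (0.19 log units; within the scatter), estimated at 60 nM within 10 nM to 400 nM.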

Compound 3, inhibition constant: 1700 nM
Compound 3: the middle estimate sits 28-fold (1.45 log units) below what was measured, outside the stated range (above it).
By their numbers in this assay, from the lowest: compound 2; then compounds 1 and 3 (each within the scatter of the next).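

In this assay, hydroxy in place of trifluoromethyl on this aromatic carbon brings a 44-fold higher number from compound 2 to compound 3 (1.64 log units; beyond the scatter) and so undoes the gain that trifluoromethyl showed over phenyl. Hydroxy and phenyl do not separate, with a 1.1-fold higher number from compound 1 to compound 3 (0.03 log units; within the scatter) and thus within the scatter, so among these three groups only trifluoromethyl stands apart. Nothing at hand explains why this position responds in this way. Still open, going by these compounds, is whether methyl, chlorine or methoxy on this carbon would fall with trifluoromethyl or with the other two groups, and where an amine would fall.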